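This account rests on a few compounds, and the source may have more. Where it says the series, first, only, none or still open, it means among the compounds named here.

Working notes on the series, step from compound 2 to compound 3.

Compound 2 `CC(/C=N/Nc1ccc([N+](=O)[O-])cc1)=N\NC(=O)c1ccccc1C` carries a methyl on the benzoyl ring. In an ADME assay on J774 cells (Mus musculus, strain BALB/c) for cytotoxicity, read by resazurin assay, with a stated time of 72 h (a lower number here means that less compound is tolerated, a higher number that more compound is tolerated), compound 2 gives > 100000 nM, which is a limit of the assay and not a number. Its neighbour compound 1 `CC(/C=N/Nc1ccc([N+](=O)[O-])cc1)=N\NC(=O)c1ccccc1Cl` differs from it only by chloro in place of methyl on that aromatic carbon. In this assay compound 1 gives > 100000 nM, again a limit. The step from compound 1 to compound 2 is therefore a step that the two limits leave unreadable from compound 1 to compound 2, and both values sit at the limit of > 100000 nM in this assay, at which 2 of the 2 values shown sit, so no size can be read from the pair.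

Compound 3 `CC(/C=N/Nc1ccc([N+](=O)[O-])cc1)=N\NC(=O)c1ccccc1N` is the next member: amino in place of methyl on an aromatic carbon. Among the measured compounds shown here, the only measured step, the one from chloro to methyl, bears on the same position but is unreadable, so there is no measured step from which a direction or size for the change to amino can be drawn.

With both measured compounds at the limit, compound 3 is expected to sit close to that limit as well, at an estimated 120000 nM with a range of 40000 nM to 400000 nM. The step this estimate means is a step that the limit leaves unreadable from compound 2 to compound 3, expected to be within the scatter, and the result is most likely to come back as a limit once more.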

Compound 3, half-maximal cytotoxic concentration: 29800 nM
Beside the measured number, compound 3's estimate is 4.0-fold (0.60 log units) above it; measured number below the stated range.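

In this assay, among the compounds shown here, this position, on an aromatic carbon ortho to a large group, is the first to show a readable change: amino in place of methyl gives an at least 3.3-fold lower number from compound 2 to compound 3 (0.52 log units; beyond the scatter), and amino in place of chloro gives an at least 3.3-fold lower number from compound 1 to compound 3 (0.52 log units; beyond the scatter). Both steps are open on one side, as compound 1 and compound 2 each stand at a limit of the assay, so less compound is tolerated with amino than with either of the other two groups, by an amount that may exceed the size printed. The step from chloro to methyl cannot be read, so compound 3 alone carries a number, and the other two compounds mark only a limit: the limit of > 100000 nM in this assay, at which 2 of the 3 values shown sit.

The compounds shown leave open whether this lower number belongs to amino in particular or would also appear with another group on the same carbon, such as a hydroxyl, a methylamino or an acetamide. As far as these compounds go, they also leave open whether amino on another carbon of this ring would give the same result, and the full size of the step stays unknown while its upper end rests on a limit.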